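The source may report more compounds than this note shows. Statements on the series, on what has been measured and on what is new or still open speak of the compounds shown alone.

Series notes. Compound 1 `Nc1cccc(/C=C2\SC(=O)N(Cc3cccc(F)c3)C2=O)c1`, compound 2 `Nc1ccc(/C=C2\SC(=O)N(Cc3ccccc3)C2=O)cc1` and compound 3 `C=C(Br)C(=O)Nc1cccc(/C=C2\SC(=O)N(Cc3ccccc3)C2=O)c1` have been run in a functional assay on L1210 cells (Mus musculus) for cytotoxicity, read by cell counting, with a stated time of 2 days; a lower number here means a stronger inhibitor, a higher number a weaker inhibitor. Compound 1 gives 199000 nM, compound 2 gives 38000 nM and compound 3 gives 380 nM. Compound 3 thus stands lowest of the three numbers; compound 2 is nearest to it, with a number higher beyond the scatter, and compound 1 is furthest, also beyond the scatter. Compound 4 `Nc1cccc(/C=C2\SC(=O)N(Cc3ccccc3)C2=O)c1` has not yet been measured in this assay. From compound 3 to compound 4 the change is hydrogen in place of (1-bromoethenyl)carbonyl on a nitrogen on an aromatic ring. Compound 1 and compound 2 each carry a free amino group on the aromatic ring and each sits far above compound 3, so the acyl group appears to account for much of what sets compound 3 apart. A large step upward, well beyond the scatter, is therefore expected on going from compound 3 to compound 4; the expected step is a 260-fold higher number from compound 3 to compound 4 (2.42 log units; beyond the scatter). For compound 4 in this assay the estimate is 100000 nM, with a range from 30000 nM to 300000 nM.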

Compound 4, half-maximal inhibitory concentration: 233000 nM
Beside the measured number, compound 4's estimate is 2.3-fold (0.37 log units) below it, within the range that was stated.
By their numbers in this assay, from the lowest: compound 3; then compound 2; then compounds 1 and 4 (each within the scatter of the next).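

In this assay, the (1-bromoethenyl)carbonyl group can now be read on its own: hydrogen in its place on the nitrogen gives a 610-fold higher number from compound 3 to compound 4 (2.79 log units; beyond the scatter) and marks a large step in a single change. Among the free amino compounds the steps are smaller: 3-aminophenyl in place of 4-aminophenyl gives a 6.1-fold higher number from compound 2 to compound 4 (0.79 log units; beyond the scatter) and is modest, while hydrogen in place of fluoro on an aromatic carbon gives a 1.2-fold higher number from compound 1 to compound 4 (0.07 log units; within the scatter) and leaves those two compounds level. No measurement shown here explains the large step.

The compounds shown leave open which part of the (1-bromoethenyl)carbonyl group carries the step, a question that an acetyl or a (1-chloroethenyl)carbonyl group on the same nitrogen would address. Also open, going by these compounds, is whether the same acyl group gives a step of similar size on the 4-aminophenyl compound.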